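This account rests on a few compounds, and the source may have more. Where it says the series, first, only, none or still open, it means among the compounds named here.

Values in an assay on CHO-K1 cells for inhibition of 11-beta-hydroxysteroid dehydrogenase type 2 (Homo sapiens), read by scintillation proximity assay; on this read-out lower numbers stand for stronger inhibition and higher numbers for weaker inhibition:

compound 1 `CCSCCC12CCC(c3nnc(-c4ccccc4C(F)(F)F)n3C)(CC1)CC2`, a limit of the assay: > 4000 nM
compound 2 `Cn1c(-c2ccccc2C(F)(F)F)nnc1C12CCC(CCCC(C)(F)F)(CC1)CC2`, a limit of the assay: > 4000 nM
compound 3 `CC(C)S(=O)(=O)CCC12CCC(c3nnc(-c4ccccc4C(F)(F)F)n3C)(CC1)CC2`, a limit of the assay: > 4000 nM

Compound 3 stands at the assay limit, as do the other two values shown (the limit of > 4000 nM in this assay, at which 3 of the 3 values shown sit). The steps a step that the two limits leave unreadable from compound 1 to compound 2, a step that the two limits leave unreadable from compound 1 to compound 3 and a step that the two limits leave unreadable from compound 2 to compound 3 are therefore unreadable in size and direction.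

Compound 4 `CCCCCC12CCC(c3nnc(-c4ccccc4C(F)(F)F)n3C)(CC1)CC2` differs from compound 3 by propyl in place of isopropylsulfonyl on a saturated chain carbon, two bonds along the chain from a saturated ring carbon. Within the data shown here, no measured step bears readably on this change; every value in this assay so far is a limit. The expectation for compound 4 in this assay is therefore a step that the limit leaves unreadable from compound 3 to compound 4, most likely again reported as a limit. Compound 4 is estimated at 10000 nM, with a range from 3000 nM to 40000 nM.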

Compound 4, half-maximal inhibitory concentration: 1300 nM
Beside the measured number, compound 4's estimate is 7.7-fold (0.89 log units) above it; measured number below the stated range.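

In this assay, among these compounds, compound 4 gives 1300 nM, the first value that is a number rather than a limit, so a change at this position can now be read: propyl in place of isopropylsulfonyl gives an at least 3.0-fold lower number from compound 3 to compound 4 (0.48 log units; beyond the scatter). Ethyl in place of 1,1-difluoroethyl gives an at least 3.0-fold lower number from compound 2 to compound 4 (0.48 log units; beyond the scatter), and propyl in place of ethylsulfanyl gives an at least 3.0-fold lower number from compound 1 to compound 4 (0.48 log units; beyond the scatter). These steps have only a lower bound, and the steps among compound 1, compound 2 and compound 3 stay unreadable, because those compounds sit at the limit: the limit of > 4000 nM in this assay, at which 3 of the 4 values shown sit.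

From the compounds shown here alone, the true size of each step remains open. Also open, going by these compounds, is whether a longer chain, an amine or a carboxylic acid at this place would lower the number further.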